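Swapping a methylphenyl sulfonamide for a thiophene sulfonamide

The source may hold more compounds than are shown below. What is called first, only, known or untested is meant among the compounds shown, and "the series" means these compounds.

Compound 2, `COc1ccc(-c2c(C)nc3c(N4CC[C@@H](NS(=O)(=O)c5ccc(C)cc5)C4)cc(C)nn23)cc1OC`, stands at the upper edge of what the measurement can report. In an ADME assay on microsomes from liver (Mus musculus) for metabolic stability, read by LC-MS, with NADPH named in the record, with a stated time of 60 min, tested at 1 uM, in the absence of a further agent (on this read-out lower numbers stand for a less stable compound and higher numbers for a more stable compound), compound 2 gives > 95%, which is a limit of the assay rather than a number. Compound 1, `COc1ccc(-c2c(C)nc3c(N4CC[C@@H](NC(=O)COc5ccccc5)C4)cc(C)nn23)cc1OC`, rests at the same limit. In this assay compound 1 gives > 95%, again a limit. The step that the two limits leave unreadable from compound 1 to compound 2 is therefore unreadable. Compound 3, `COc1ccc(-c2c(C)nc3c(N4CC[C@@H](NS(=O)(=O)c5cccs5)C4)cc(C)nn23)cc1OC`, differs from compound 2 by thiophen-2-yl in place of 4-methylphenyl on a sulfonyl sulfur. Among the compounds with values here, no measured step bears directly on this change, and both known values sit at the same limit (the limit of > 95% in this assay, at which 2 of the 2 values shown sit). Compound 3 is expected to stay near that limit, with an estimated step of a number at least 1 percentage points lower from compound 2 to compound 3 (that floor lies within the scatter). The estimate for compound 3 is 94%, between 80% and 99%.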

Compound 3, percent of the compound remaining: > 95%
Compound 3: no number, only a limit; the forecaster's own chance of this, stated with the estimate: 60%; middle value at least 1 percentage points from the limit.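

Compound 3 also gives a limit of the assay rather than a number, so no step among compound 1, compound 2 and compound 3 can be read: the limit of > 95% in this assay, at which 3 of the 3 values shown sit.

On these data alone, whether thiophen-2-yl and 4-methylphenyl differ at all in this assay stays open.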